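Swapping the aryl group on the sulfonyl sulfur

The compounds below may be only part of what the source reports. "The series", "measured", "known", "first", "only" and "open" are said of these compounds alone.

Compound 1 `COc1ccc(S(=O)(=O)c2cnc3c(F)cccc3c2-c2cccc(Cl)c2)cc1` was tested in an ADME assay on microsomes from liver (Homo sapiens) for metabolic stability, tested at 2.5 uM (on this read-out lower numbers stand for slow clearance and higher numbers for fast clearance), where compound 1 gives 2.75 mL/min. For the measured compounds named here, of the two numbers recorded so far this is the highest, yet the only neighbour, compound 2 `COc1ccc(-c2c(S(=O)(=O)c3ccc(OC)cc3)cnc3c(F)cccc23)cc1`, gives 2.12 mL/min, and the step of a 1.3-fold lower number from compound 1 to compound 2 (0.11 log units; within the scatter) stays within the scatter, so the two cannot truly be told apart. That step puts 4-methoxyphenyl in place of 3-chlorophenyl on an aromatic carbon. Compound 3 `O=S(=O)(c1ccc(F)c(F)c1)c1cnc2c(F)cccc2c1-c1cccc(Cl)c1` has not yet been measured. It differs from compound 1 by 3,4-difluorophenyl in place of 4-methoxyphenyl on a sulfonyl sulfur. Going by the values given here, no measured step touches the group on the sulfonyl sulfur, so the single pair seen gives no direct guide, and that pair itself moved nowhere beyond the scatter. Compound 3 is therefore expected to give about 2.7 mL/min in this assay, with an expected range from 1.4 mL/min to 5.5 mL/min. The expected step of a 1.0-fold lower number from compound 1 to compound 3 (0.01 log units; within the scatter) amounts to none beyond the scatter.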

Compound 3, intrinsic clearance in a liver preparation (reported as CLH), per the amount of preparation that the assay uses: 1.13 mL/min
Beside the measured number, compound 3's estimate is 2.4-fold (0.38 log units) above it, and the stated range ends above it.
By their numbers in this assay, from the lowest: compounds 3, 2 and 1 (each within the scatter of the next, the first and the last beyond it).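

The group on the sulfonyl sulfur proves to be a place where a single change can move the number in this assay: replacing 4-methoxyphenyl with 3,4-difluorophenyl gives a 2.4-fold lower number from compound 1 to compound 3 (0.39 log units; beyond the scatter). For the compounds shown here, the only earlier step, at the aromatic carbon, stayed within the scatter, with a 1.3-fold lower number from compound 1 to compound 2 (0.11 log units; within the scatter). Both groups hold 8 heavy atoms and one six-membered aromatic ring of carbon only, so the swap leaves these counts unchanged while the hydrogen-bond acceptor of the leaving group is gone, and nothing available here bears on why the number falls.

The compounds shown do not separate the loss of the methoxy group from the arrival of the two fluorines. From the compounds shown here alone, how a plain phenyl, a pyridine ring or a cyclopropyl group on the sulfonyl sulfur would read also remains open.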